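The source may hold more compounds than are shown below. What is called first, only, known or untested is meant among the compounds shown, and "the series" means these compounds.

Compound 1 `O[C@@H]1Cc2ccccc2N[C@H](c2ccc(Cl)cc2)C1` gives 114000 nM in an ADME assay on THP-1 cells (Homo sapiens) for cytotoxicity, read by MTT assay, with a stated time of 72 h; a higher number here means that more compound is tolerated, a lower number that less compound is tolerated.
Compound 2 `O[C@@H]1Cc2ccccc2N[C@H](c2ccc(F)cc2)C1` gives > 300000 nM, which is a limit of the assay rather than a number.
Compound 3 `O[C@@H]1Cc2cc(Cl)ccc2N[C@H](c2ccccc2Cl)C1` gives 75500 nM.

The change from compound 1 to compound 2 is fluoro in place of chloro on an aromatic carbon. It brought an at least 2.6-fold higher number from compound 1 to compound 2 (0.42 log units; beyond the scatter), and the step can only be given as a lower bound because compound 2 sits at the limit of > 300000 nM in this assay, at which 1 of the 3 values shown sits. Compound 3 stands close to compound 1; the difference between the two cores is not broken down here.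

Compound 4 `O[C@@H]1Cc2cc(Cl)ccc2N[C@H](c2ccccc2F)C1` has not been measured. It differs from compound 3 by fluoro in place of chloro on an aromatic carbon, the same kind of change as that from compound 1 to compound 2, but here the fluoro sits ortho to a large group rather than para to it, and the core also carries its own chloro. Resting on the single earlier step, compound 4 is expected to show a 2.0-fold higher number from compound 3 to compound 4 (0.30 log units; within the scatter). The estimate for compound 4 is 150000 nM, expected to fall between 60000 nM and 300000 nM.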

Compound 4, half-maximal cytotoxic concentration: 110000 nM
Compound 4: middle estimate off by 1.4-fold (0.13 log units), on the high side; the range from low to high includes it.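

On the core of compound 3, fluoro in place of chloro on an aromatic carbon, ortho to a large group, reads in this assay as a 1.5-fold higher number from compound 3 to compound 4 (0.16 log units; within the scatter), so on this core the change cannot be told apart from the usual scatter. Set beside the earlier step, this shows neither that the clear step on the core of compound 1 carries over nor that the two cores respond differently: the same change on two cores in this assay, an at least 2.6-fold higher number (0.42 log units; beyond the scatter) from compound 1 to compound 2 and a 1.5-fold higher number (0.16 log units; within the scatter) from compound 3 to compound 4; the limit leaves it open whether they differ Compound 2 gives > 300000 nM, which is a limit of the assay and not a number, and with only two pairs the series supports no rule for this change.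

The compounds shown leave open how a methyl, a methoxy or a nitrile at the same aromatic carbon would read in this assay. They also leave open what an amine or a carboxylic acid in place of the hydroxyl on the shared core would do.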